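Fluorophenyl variations and cytotoxicity on a shared indole-derived core

The source may report more compounds than this note shows. Statements on the series, on what has been measured and on what is new or still open speak of the compounds shown alone.

Measured so far in an ADME assay on MT4 cells (Homo sapiens) for cytotoxicity, read by MTT assay; on this read-out lower numbers stand for higher toxicity in this test and higher numbers for lower toxicity in this test:
- compound 1, `COc1cccc2c1c(C(=O)/C=C(\O)C(=O)O)cn2Cc1cc(F)ccc1F`, gives 46200 nM
- compound 2, `COc1cccc2c1c(C(=O)/C=C(\O)C(=O)O)cn2Cc1ccc(F)cc1`, gives 41100 nM
- compound 3, `COc1cccc2c1c(C(=O)/C=C(\O)C(=O)O)cn2Cc1cc(F)c(F)c(F)c1`, gives 23300 nM

Compound 3 sits at the lower end of these three numbers, yet the steps of a 2.0-fold lower number from compound 1 to compound 3 (0.30 log units; within the scatter) and a 1.8-fold lower number from compound 2 to compound 3 (0.25 log units; within the scatter) both fall within the scatter, so no real gap separates it from compounds 1 and 2. Compound 4, `COc1cccc2c1c(C(=O)/C=C(\O)C(=O)O)cn2Cc1ccc(F)cc1F`, differs from compound 3 only by 2,4-difluorophenyl in place of 3,4,5-trifluorophenyl on a saturated chain carbon bound to an aromatic nitrogen. Every measured exchange of one fluorinated phenyl for another, including a 1.1-fold lower number from compound 1 to compound 2 (0.05 log units; within the scatter), has stayed within the scatter, so no movement beyond the scatter is expected in this assay for this step, a 1.6-fold higher number from compound 3 to compound 4 (0.21 log units; within the scatter). Compound 4 is therefore estimated at 38000 nM, with a likely range from 18000 nM to 80000 nM.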

Compound 4, half-maximal cytotoxic concentration: 20800 nM
The estimate for compound 4 lay 1.8-fold (0.26 log units) above the measured number; measured number inside the range.
By their numbers in this assay, from the lowest: compounds 4, 3, 2 and 1 (each within the scatter of the next, the first and the last beyond it).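

Moving from 3,4,5-trifluorophenyl to 2,4-difluorophenyl on this saturated chain carbon (a 1.1-fold lower number from compound 3 to compound 4 (0.05 log units; within the scatter)) and placing fluoro in place of hydrogen on an aromatic carbon (a 2.0-fold lower number from compound 2 to compound 4 (0.30 log units; within the scatter)) both stay within the scatter. Among these compounds, the exchange of 2,5-difluorophenyl for 2,4-difluorophenyl (a 2.2-fold lower number from compound 1 to compound 4 (0.35 log units; beyond the scatter)) is the first step here beyond the scatter, though only a modest one, so two phenyl groups with the same count of fluorines can be told apart. Nothing available explains this difference.

Still open is how a phenyl ring carrying chloro or methyl groups would read in this test, since every group shown at this position carries only fluorine.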